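This account rests on a few compounds, and the source may have more. Where it says the series, first, only, none or still open, it means among the compounds named here.

Three compounds sharing one core were measured in a functional assay on spleen for agonist activity at Alpha-1B adrenergic receptor (Rattus norvegicus); a lower number here means a less potent compound, a higher number a more potent compound, by a factor of ten per unit of this negative logarithm. Compound 1 `CN(c1cccc2c1CCCC2c1c[nH]cn1)S(C)(=O)=O` gives 5.65. Compound 2 `CC(=O)Nc1cccc2c1CCCC2c1c[nH]cn1` gives 4.84, the lowest of the three numbers. Compound 3 `O=C(Nc1cccc2c1CCCC2c1c[nH]cn1)C(F)(F)F` gives 5.47, the second highest of the three; its nearest neighbour is compound 1, and the step of a number 0.18 log units lower from compound 1 to compound 3 (within the scatter) stays within the scatter, whereas a number 0.63 log units higher from compound 2 to compound 3 (beyond the scatter) lies beyond it. The remaining step, a number 0.81 log units lower from compound 1 to compound 2 (beyond the scatter), is likewise beyond the scatter.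

Compound 4 `Nc1cccc2c1CCCC2c1c[nH]cn1` has not been measured in this assay. It differs from compound 3 in one place: hydrogen in place of (trifluoromethyl)carbonyl on a nitrogen on an aromatic ring. For the measured compounds named here, no measured step removes the group on that nitrogen altogether; the steps that bear on it only exchange one such group for another. Of these, a number 0.63 log units higher from compound 2 to compound 3 (beyond the scatter) and a number 0.81 log units lower from compound 1 to compound 2 (beyond the scatter) show that what stands on the nitrogen moves the number by modest amounts, while a number 0.18 log units lower from compound 1 to compound 3 (within the scatter) shows two of the groups to be interchangeable. Because compound 2 gives the lowest number, 4.84, and compound 4 carries only hydrogen there, a downward step beyond the scatter is expected. The estimate for compound 4 is therefore 4.9, and compound 4 is expected to fall between 4.3 and 5.6. The expected step is a number 0.57 log units lower from compound 3 to compound 4 (beyond the scatter).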

Compound 4, negative logarithm of the half-maximal effective concentration: 6.01
Estimate against measurement, compound 4: 1.11 log units below; measured number above the stated range.
By their numbers in this assay, from the lowest: compound 2; then compounds 3 and 1 (each within the scatter of the next); then compound 4.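

In this assay, taking away what stands on the nitrogen on the aromatic ring does not lower the number but raises it in every comparison, with a number 0.54 log units higher from compound 3 to compound 4 (beyond the scatter) and with a number 1.17 log units higher from compound 2 to compound 4 (beyond the scatter) and with a number 0.36 log units higher from compound 1 to compound 4 (beyond the scatter) pointing the same way. The earlier compounds shown here only exchanged one group on this nitrogen for another, so they could rank acetyl against (trifluoromethyl)carbonyl and the methyl and methylsulfonyl pair, but could not show that the unsubstituted amino compound stands above all three. Among these compounds, none of the groups tried on the nitrogen matches plain hydrogen, and the step from acetyl to hydrogen is the only one of the three printed as large, while the other two are modest.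

Going by these compounds, it remains open whether a small group such as a single methyl or an ethyl on that nitrogen, or a methylsulfonyl with the nitrogen's hydrogen kept, would hold the number of compound 4 or lose part of it. Why hydrogen does best here also stays open, as no measurement offered alongside these numbers addresses it.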